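Ester variation at the hydroxyethyl side chain and cell tolerance

The source may report more compounds than this note shows. Statements on the series, on what has been measured and on what is new or still open speak of the compounds shown alone.

Measured compounds:
- compound 1 `O=c1[nH]c2ccc(Cl)cc2c(-c2ccccc2Cl)c1CCO`: 380000 nM
- compound 2 `O=C(OCCc1c(-c2ccccc2Cl)c2cc(Cl)ccc2[nH]c1=O)C1CCCC1`: 46000 nM

Two compounds share a core and differ only in what sits on the side-chain oxygen. In an ADME assay on HepG2 2.2.15 cells (Homo sapiens) for cytotoxicity (a higher number here means that more compound is tolerated, a lower number that less compound is tolerated), compound 1 gives 380000 nM, and compound 2 gives 46000 nM. Going by the values given here, the single measured step, an 8.3-fold lower number from compound 1 to compound 2 (0.92 log units; beyond the scatter), came with cyclopentylcarbonyl in place of hydrogen on that oxygen, so compound 2 stands at the lowest of the two numbers, with compound 1 as its nearest neighbour.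

Compound 3 `O=C(COc1ccccc1)OCCc1c(-c2ccccc2Cl)c2cc(Cl)ccc2[nH]c1=O` keeps the ester of compound 2 but changes the group on the carbonyl carbon: phenoxymethyl in place of cyclopentyl on a carbonyl carbon. Among the compounds with values here, both compounds thus carry an ester at the same place, and no measured step separates one ester from another; the only step on record concerns the ester versus the free alcohol. The change from compound 2 to compound 3 is therefore expected to be small, within the scatter or at most a modest shift, as a 1.3-fold lower number from compound 2 to compound 3 (0.12 log units; within the scatter). On that basis compound 3 is estimated at 35000 nM, with a range from 12000 nM to 120000 nM.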

Compound 3, half-maximal cytotoxic concentration: 81000 nM
Beside the measured number, compound 3's estimate is 2.3-fold (0.36 log units) below it; measured number inside the range.
By their numbers in this assay, from the lowest: compounds 2 and 3 (each within the scatter of the next); then compound 1.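

In this assay, the change on the carbonyl carbon gives a 1.8-fold higher number from compound 2 to compound 3 (0.25 log units; within the scatter) and so stays within the scatter, even though phenoxymethyl brings 8 heavy atoms in place of the 5 of cyclopentyl, an aromatic ring in place of a non-aromatic one, and a hydrogen-bond acceptor that cyclopentyl lacks. Compound 3 also sits apart from the free alcohol, with a 4.7-fold lower number from compound 1 to compound 3 (0.67 log units; beyond the scatter) as the step beyond the scatter, so the lower number seen with the first ester appears again with a second, quite different ester, and among these three compounds the two esters fall together on one side and the alcohol on the other. Nothing in the data shown explains either step, so what lies behind them remains unknown.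

As far as these compounds go, both esters here carry a ring on the acyl part, so it remains open whether a small acetyl ester, a long straight chain or an acyl group bearing an amine or a carboxylic acid would fall with compound 2 and compound 3. From the compounds shown here alone, it is also open whether the lower number depends on the ester link itself, which an amide or an ether at the same place could test.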